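The source may hold more compounds than are shown below. What is called first, only, known or untested is meant among the compounds shown, and "the series" means these compounds.

Compound 1 `O=C(c1cccnc1)N1N=C(c2ccc(O)cc2)CC1c1ccc(F)cc1` was tested in an ADME assay on HepG2 cells (Homo sapiens) for cytotoxicity, read by MTT assay, with a stated time of 7 days (a lower number here means a stronger inhibitor, a higher number a weaker inhibitor), where compound 1 gives 52400 nM, the highest of the three numbers here. Compound 2 `CC(C)c1ccccc1C1CC(c2ccc(O)cc2)=NN1C(=O)c1cccnc1` gives 49700 nM and compound 3 `CCc1ccccc1C1CC(c2ccc(O)cc2)=NN1C(=O)c1cccnc1` gives 35400 nM; the two steps of a 1.1-fold lower number from compound 1 to compound 2 (0.02 log units; within the scatter) and a 1.5-fold lower number from compound 1 to compound 3 (0.17 log units; within the scatter) both stay within the scatter, as does a 1.4-fold lower number from compound 2 to compound 3 (0.15 log units; within the scatter). Compound 4 `COc1ccc(OC)c(C2CC(c3ccc(O)cc3)=NN2C(=O)c2cccnc2)c1` differs from compound 1 in one place: 2,5-dimethoxyphenyl in place of 4-fluorophenyl on a saturated ring carbon. The swaps to compound 2 and compound 3 exchanged the group on the same saturated ring carbon and left this assay essentially unchanged, so for compound 4 no step beyond the scatter is expected. Compound 4 is therefore estimated at 45000 nM, within 20000 nM to 100000 nM, an expected step of a 1.2-fold lower number from compound 1 to compound 4 (0.07 log units; within the scatter).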

Compound 4, half-maximal inhibitory concentration: 56800 nM
Compound 4: the middle estimate sits 1.3-fold (0.10 log units) below what was measured; low and high end bracket the measured number.
By their numbers in this assay, from the lowest: compounds 3, 2, 1 and 4 (each within the scatter of the next).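

Putting 2,5-dimethoxyphenyl, with its two oxygen atoms, on the saturated ring carbon gives a 1.1-fold higher number from compound 1 to compound 4 (0.04 log units; within the scatter) and stays within the scatter, as do a 1.1-fold higher number from compound 2 to compound 4 (0.06 log units; within the scatter) and a 1.6-fold higher number from compound 3 to compound 4 (0.21 log units; within the scatter). This position therefore accepts a group with hydrogen-bond acceptors, which 4-fluorophenyl lacks, with no step beyond the scatter among these four compounds. Nothing available here explains this. Going by these compounds, whether an amine or a carboxylic acid on this phenyl ring would give a larger step stays open. So does the effect of changing the 4-hydroxyphenyl or (pyridin-3-yl)carbonyl group.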